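A few compounds are considered here, and "the series" means these few. Any claim that something is new, unique, unknown or untested is made for them only; others in the source may bear on it.

Measured so far in an ADME assay on MDCK cells (Canis lupus familiaris) for cytotoxicity; a lower number here means that less compound is tolerated, a higher number that more compound is tolerated:
Compound 1 `Cn1ccnc1Sc1cnc(-c2ccccc2)nc1-c1ccccc1O`: 120000 ug/mL
Compound 2 `Cn1cnnc1Sc1cnc(C(C)(C)C)nc1-c1ccccc1O`: 160000 ug/mL

Within the data shown here, of these two numbers, the one for compound 2 is the higher, yet the gap to compound 1 lies within the usual scatter, so the two compounds tolerate about the same amount. Compound 3 `Cn1ccnc1Sc1cnc(C(C)(C)C)nc1-c1ccccc1O` has not yet been measured. It differs from compound 2 by 1-methyl-1H-imidazol-2-yl in place of 4-methyl-4H-1,2,4-triazol-3-yl on a sulfur. Among the measured compounds shown here, with no measured pair showing this change on its own, nothing points to a shift beyond the scatter in either direction. The step expected here, a 1.2-fold lower number from compound 2 to compound 3 (0.09 log units; within the scatter), should stay within that scatter. Compound 3 is therefore estimated at 130000 ug/mL, in the range 60000 ug/mL to 260000 ug/mL.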

Compound 3, half-maximal cytotoxic concentration: 194000 ug/mL
For compound 3 the middle estimate is 1.5-fold (0.17 log units) below the measured one, and the stated range covers the measured number.
By their numbers in this assay, from the lowest: compounds 1, 2 and 3 (each within the scatter of the next).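

In this assay, among these compounds, 1-methyl-1H-imidazol-2-yl in place of 4-methyl-4H-1,2,4-triazol-3-yl on a sulfur gives a 1.2-fold higher number from compound 2 to compound 3 (0.08 log units; within the scatter) as the first direct reading of this change, which lies within the scatter. With that sulfur group held the same, tert-butyl in place of phenyl on an aromatic carbon gives a 1.6-fold higher number from compound 1 to compound 3 (0.21 log units; within the scatter), also within the scatter, so neither change separates these compounds. Nothing measured here offers an explanation for either step.

On these data alone, whether an amine or a longer chain in place of tert-butyl, or a pyridine ring on the sulfur, would move the number beyond the scatter remains open.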